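The compounds below may be only part of what the source reports. "The series", "measured", "known", "first", "only" and "open" are said of these compounds alone.

Compounds measured in an assay on isolated protein for agonist activity at Bile acid receptor (Homo sapiens), read by AlphaScreen, with a stated time of 30 min; a lower number here means that less compound is needed, a higher number that more compound is needed for the effect:
Compound 1, `Cc1ccccc1-n1nc(C)c2c1NC(=O)[C@H](C)S[C@@H]2c1ccc(-c2ccco2)cc1`: 3600 nM
Compound 2, `COc1cccc(Oc2ccc([C@H]3S[C@@H](C)C(=O)Nc4c3c(C)nn4-c3ccccc3C)cc2)c1`: 1700 nM

Among the two measured numbers, compound 2 stands lowest; its nearest neighbour is compound 1, and the only measured step is a 2.1-fold lower number from compound 1 to compound 2 (0.33 log units; beyond the scatter). Compound 3, `COC(=O)c1ccc(-c2ccc([C@H]3S[C@@H](C)C(=O)Nc4c3c(C)nn4-c3ccccc3C)cc2)cc1`, has not yet been measured in this assay. It differs from compound 2 by 4-(methoxycarbonyl)phenyl in place of 3-methoxyphenoxy on an aromatic carbon. For the measured compounds named here, the single measured step bears on this change only loosely: it shows that exchanging one substituent for another on that aromatic carbon moved the number by a modest amount, from compound 1 to compound 2, without indicating how a 4-(methoxycarbonyl)phenyl group would behave. A step from compound 2 to compound 3 of no more than that size, in either direction, is therefore expected, with the estimate centred close to compound 2. Compound 3 is estimated at 1500 nM, with a range of 500 nM to 4500 nM, which corresponds to an expected step of a 1.1-fold lower number from compound 2 to compound 3 (0.05 log units; within the scatter).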

Compound 3, half-maximal effective concentration: "not active" (no number reported)
Nothing numeric was reported for compound 3, and the estimate cannot be compared.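

In this assay, for the compounds shown here, compound 3 was reported as "not active" with no number, so no step from compound 2 to compound 3 can be read. Nothing available explains this result. The compounds shown leave open which feature of the 4-(methoxycarbonyl)phenyl group goes with this outcome.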